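This account rests on a few compounds, and the source may have more. Where it says the series, first, only, none or still open, it means among the compounds named here.

Compound 1 `CN1CCCN(S(=O)(=O)c2ccc(-c3ccc4c(Nc5ccc(OCc6cccc(F)c6)c(Cl)c5)nncc4c3)cc2)CC1` was tested in a toxicity assay on HepG2 cells (Homo sapiens) for cytotoxicity, read by MTT assay, with a stated time of 48 h (on this read-out higher numbers stand for lower toxicity in this test and lower numbers for higher toxicity in this test), where compound 1 gives 3.4 uM. This is the lower of the two numbers in hand: compound 2 `CN1CCCN(S(=O)(=O)c2ccc(-c3ccc4nncc(Nc5ccc(OCc6cccc(F)c6)c(Cl)c5)c4c3)cc2)CC1`, in this assay, gives 7.3 uM, a higher value that lies beyond the scatter. Compound 3 `CN1CCN(S(=O)(=O)c2ccc(-c3ccc4c(Nc5ccc(OCc6cccc(F)c6)c(Cl)c5)nncc4c3)cc2)CC1` has not been measured. It differs from compound 1 in one place: 4-methylpiperazin-1-yl in place of 4-methyl-1,4-diazepan-1-yl on a sulfonyl sulfur. Among the measured compounds shown here, with no measured pair showing the effect of this change, the step is expected to be small, a 1.2-fold higher number from compound 1 to compound 3 (0.07 log units; within the scatter), in no direction beyond the scatter. Compound 3 is therefore estimated at 4 uM, within a range from 1.5 uM to 10 uM.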

Compound 3, half-maximal toxic concentration: > 15 uM
Compound 3: only a limit was reported; the forecaster's own chance of this, stated with the estimate: 5%; middle value at least 3.7-fold (0.57 log units) from the limit.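

In this assay, the group on the sulfonyl sulfur proves not to be a neutral place for change: going from the seven-membered ring to the six-membered ring gives an at least 4.4-fold higher number from compound 1 to compound 3 (0.64 log units; beyond the scatter) and so lower toxicity in this test. For compound 3 the reported > 15 uM is a limit and not a number, so the full size of the step cannot be read: the limit of > 15 uM in this assay, at which 1 of the 3 values shown sits.

From the compounds shown here alone, whether an open-chain amine such as dimethylamino or a morpholine ring would behave like 4-methylpiperazin-1-yl remains open. So does whether the same ring change would carry over to the core of compound 2.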